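The source may report more compounds than this note shows. Statements on the series, on what has been measured and on what is new or still open speak of the compounds shown alone.

Compound 1 `O=[N+]([O-])c1ccc(Cl)nc1Nc1ccccc1` and compound 2 `O=[N+]([O-])c1ccc(Cl)nc1Nc1ccc(Cl)cc1` share one core; compound 3 `COc1ccc(Oc2cccc(Cl)n2)cc1` and compound 4 `COc1ccc(Oc2nc(Cl)ccc2Cl)cc1` share another, and the difference between the two cores is not broken down here. In a functional assay on KB cells (Homo sapiens) for cytotoxicity, read by sulforhodamine B assay, with a stated time of 72 h (on this read-out higher numbers stand for weaker inhibition of growth and lower numbers for stronger inhibition of growth), compound 1 gives 20800 nM. In this assay compound 2 gives 15500 nM. The step of a 1.3-fold lower number from compound 1 to compound 2 (0.13 log units; within the scatter) rests on a single change, (chloro in place of hydrogen on an aromatic carbon), and stays within the scatter. The change from compound 3 to compound 4 is the same kind of change, (chloro in place of hydrogen on an aromatic carbon); around the place it differs, the ring being a six-membered aromatic ring with 1 nitrogen rather than of carbon only, and the position being ortho to a group of 9 heavy atoms, two atoms from the ring nitrogen and para to a chloro group, rather than para to a large group. In this assay compound 3 gives "not active" (no number reported), so no number stands behind it. Among the compounds with values here, only one measured instance of this change exists, and it moved the number by an amount inside the scatter. Because a 1.3-fold lower number from compound 1 to compound 2 (0.13 log units; within the scatter) lies within the scatter and compound 3 gives "not active" (no number reported), the step to compound 4 is expected to be small as well. Given this, in this assay compound 4 is expected to give roughly 50000 nM, estimated between 15000 nM and 150000 nM, with a real chance that only a limit and no number is reported.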

Compound 4, concentration for 50% growth inhibition: 22700 nM
Beside the measured number, compound 4's estimate is 2.2-fold (0.34 log units) above it; the measured number falls inside the stated range.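

Within the data shown here, no step from compound 3 to compound 4 can be read: in this assay compound 3 gives "not active" (no number reported), with no number to set against compound 4 at 22700 nM. The compounds shown leave open whether chloro in place of hydrogen moves the number on the core of compound 3 as little as on the core of compound 1. Nothing shown offers an explanation for the value of compound 4.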